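Tetrazolyl in place of hydrogen on the core of compound 1

The source may hold more compounds than are shown below. What is called first, only, known or untested is meant among the compounds shown, and "the series" means these compounds.

Measured compounds:
compound 1 `CC(C)(C)c1ccc(NC(=O)c2ccc(-c3ccccn3)cc2)cc1` — in a functional assay for antagonist activity at transient receptor potential cation channel subfamily V member 1 (Homo sapiens), read by FLIPR (a higher number here means a weaker inhibitor, a lower number a stronger inhibitor), compound 1 gives 11 nM
compound 2 `CC(C)(C)c1ccc(NC(=O)c2ccc(-c3ncccc3C(=O)O)cc2)cc1` — compound 2 gives only a limit, > 4000 nM

Within the data shown here, compound 1 holds the only number in this assay; the other entry is a limit, not a number. Carboxy in place of hydrogen on an aromatic carbon moves the read-out an at least 360-fold higher number from compound 1 to compound 2 (2.56 log units; beyond the scatter), and compound 2 sits at the limit of > 4000 nM in this assay, at which 1 of the 2 values shown sits. Compound 3 `CC(C)(C)c1ccc(NC(=O)c2ccc(-c3ncccc3-c3nn[nH]n3)cc2)cc1` carries the change (2H-tetrazol-5-yl in place of hydrogen on an aromatic carbon), at the same place where compound 2 carries its carboxy. Among the measured compounds shown here, the carboxy step is the only measured step that bears on this change; it was large and toward a weaker inhibitor, and the entering 2H-tetrazol-5-yl is likewise a five-membered aromatic ring with hetero atoms replacing a bare hydrogen. A large loss is therefore expected, a 270-fold higher number from compound 1 to compound 3 (2.44 log units; beyond the scatter). Compound 3 is estimated at 3000 nM, within 300 nM to 20000 nM, and the assay may well report only a limit for it.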

Compound 3, half-maximal inhibitory concentration: > 4000 nM
Compound 3: only a limit was reported; the forecaster's own chance of this, stated with the estimate: 45%; middle value at least 1.3-fold (0.12 log units) away from the limit.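

In this assay, the loss seen with carboxy at this place is not unique to that group: 2H-tetrazol-5-yl on the same aromatic carbon, ortho to a large group and two atoms from the ring nitrogen, gives an at least 360-fold higher number from compound 1 to compound 3 (2.56 log units; beyond the scatter). The value for compound 3 is a limit, so this step gives only a minimum size. Both groups tried at this place therefore lose the measurable inhibition of compound 1, and neither listed compound goes against that, though the pattern rests on only two groups. Compound 2 and compound 3 both end at a limit, and the step between them cannot be read: the limit of > 4000 nM in this assay, at which 2 of the 3 values shown sit.

On these data alone, how the two groups rank remains open. A small group such as methyl, fluorine or an amine at this place would show whether any group is accepted there.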